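The source may hold more compounds than are shown below. What is called first, only, known or untested is meant among the compounds shown, and "the series" means these compounds.

Compound 1 `CC(C)(C)C/N=C(/NC#N)Nc1cccnc1` and compound 2 `CCC(C)/N=C(\NC#N)Nc1cccnc1` share one core and differ in the group on the double-bonded nitrogen. In a functional assay on the whole organism (blood, strain Wistar-Okamoto) with Rattus norvegicus as the target, with a stated time of 5 days (on this read-out higher numbers stand for an effect only at larger amounts of compound and lower numbers for an effect already at smaller amounts), compound 1 gives 2.5 mg/kg, and compound 2 gives 20 mg/kg, the higher of the two numbers, with the gap to compound 1 beyond the scatter. Compound 3 `N#CN/C(=N\c1ccccc1)Nc1cccnc1` carries phenyl in place of sec-butyl on a double-bonded nitrogen. Among the compounds with values here, no measured pair shows such a change, so the step is expected to be small: a 1.3-fold lower number from compound 2 to compound 3 (0.12 log units; within the scatter) is estimated as no step beyond the scatter, or a modest one. Compound 3 is therefore expected to give about 15 mg/kg, within 4 mg/kg to 60 mg/kg.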

Compound 3, minimum effective dose: 5 mg/kg
Estimate against measurement, compound 3: 3.0-fold (0.48 log units) above; the measured number falls inside the stated range.
By their numbers in this assay, from the lowest: compounds 1 and 3 (each within the scatter of the next); then compound 2.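

In this assay phenyl in place of sec-butyl on a double-bonded nitrogen brings a 4.0-fold lower number from compound 2 to compound 3 (0.60 log units; beyond the scatter) and so shows that this position responds when an open chain gives way to an aromatic ring. Compound 3 stands within the scatter of compound 1, so a ring here reaches the same low range as the group of compound 1. Nothing at hand accounts for the step. From the compounds shown here alone, whether a chlorophenyl group, a cyclohexyl ring or a longer chain at this position would give a lower or higher number stays open. So does whether an amine would be tolerated there.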